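The compounds below may be only part of what the source reports. "The series", "measured", "known", "first", "only" and "open" are said of these compounds alone.

The compounds measured so far:

Compound 1, `CCCCCCCC#CC#CC1=CC(=O)NCCC1`. In a functional assay on A549 cells (Homo sapiens) for cytotoxicity (on this read-out higher numbers stand for an effect only at larger amounts of compound and lower numbers for an effect already at smaller amounts), compound 1 gives > 50 ug/mL, which is a limit of the assay rather than a number.

Compound 2, `C=CCCCCCCCC#CC#C/C=C\C(C)=O`. In this assay compound 2 gives > 50 ug/mL, again a limit rather than a number.

Compound 2 therefore stands at the limit of > 50 ug/mL in this assay, at which 2 of the 2 values shown sit. Going by the values given here, no single-change step between measured compounds is available here, so the shape of the chain end has not yet been tested on its own.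

Compound 3, `CCCCCCCC#CC#C/C=C\C(C)=O`, differs from compound 2 in one place: hydrogen in place of vinyl on a saturated chain carbon, seven bonds along the chain from a triple-bonded carbon. Among the compounds with values here, both compounds measured so far sit at the same limit, and nothing in the data points in either direction, so in this assay no step beyond the usual scatter is expected from this change. Compound 3 is expected to give about 80 ug/mL, with a range from 30 ug/mL to 300 ug/mL, most likely reported again only as a limit. The expected step is a step that the limit leaves unreadable from compound 2 to compound 3.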

Compound 3, concentration for half-maximal effect: > 50 ug/mL
Compound 3: no number, only a limit (the forecaster's own chance of this, stated with the estimate: 85%); the middle value does not contradict the limit.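

Compound 2 and compound 3 both stop at a limit of the assay rather than a number, so no step can be read for hydrogen in place of vinyl: the limit of > 50 ug/mL in this assay, at which 3 of the 3 values shown sit.

The compounds shown leave open whether the vinyl end changes anything in this assay, and what number any of them would give.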